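From Methylamino to Amino in a Small Series

This account rests on a few compounds, and the source may have more. Where it says the series, first, only, none or still open, it means among the compounds named here.

Three compounds have values in a functional assay on A2780 cells (Homo sapiens) for antiproliferative activity, read by MTT assay, with a stated time of 48 h; on this read-out lower numbers stand for stronger inhibition and higher numbers for weaker inhibition. There, compound 1 (`COc1ccc(C(=O)c2ccc(OC)c3c2OC(C)(C)C=C3)c(NC(=O)CBr)c1`) gives 980 nM, compound 2 (`CNCC(=O)Nc1cc(OC)ccc1C(=O)c1ccc2c(c1)C=CC(C)(C)O2`) gives 850 nM and compound 3 (`CNCC(=O)Nc1cc(OC)ccc1C(=O)c1cc(OC)c(OC)c(OC)c1`) gives 580 nM. Compound 3 lies within the scatter of both of the others, so these numbers do not separate it from either one.

The next compound to be tested is compound 4 (`COc1ccc(C(=O)c2cc(OC)c(OC)c(OC)c2)c(NC(=O)CN)c1`), which has no value yet. Its structure departs from that of compound 3 at a single place: hydrogen in place of methyl on an amine nitrogen. In words, hydrogen stands in place of methyl on an amine nitrogen.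

Among the measured compounds shown here, no measured pair shows this change alone, so the data give no direct precedent for it. For the measured compounds named here, the only guide is how closely the measured values sit, with compound 2 at 850 nM and compound 3 at 580 nM both carrying the methylamino group. On that basis, no step beyond the scatter is expected in this assay, and no direction is favoured. The estimated move is a 1.0-fold higher number from compound 3 to compound 4 (0.01 log units; within the scatter). Compound 4 is expected to give about 600 nM, with an estimated range from 200 nM to 1800 nM.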

Compound 4, half-maximal inhibitory concentration: 190 nM
The estimate for compound 4 lay 3.2-fold (0.50 log units) above the measured number, and the stated range ends above it.
By their numbers in this assay, from the lowest: compound 4; then compounds 3, 2 and 1 (each within the scatter of the next).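

Among the compounds shown here, replacing methylamino with amino gives a 3.1-fold lower number from compound 3 to compound 4 (0.48 log units; beyond the scatter) in this assay, and this is the first step that lies beyond the scatter. The earlier compounds shown here sat within the scatter of one another and no two of them differed in one place, so they could not show that this amine nitrogen matters; the pair now shows that losing a single methyl there, one carbon on a nitrogen whose other neighbour is a saturated chain carbon, moves the number by a modest but readable amount. Nothing in the available data accounts for this step, and it stands as an observation from one pair.

As far as these compounds go, whether the same change would carry over to the core of compound 2, which also bears methylamino, remains open, as a single pair sets no general pattern. Also open, from the compounds shown here alone, is how the read-out would respond to an ethylamino or dimethylamino group at this place, or to a longer chain in place of aminomethyl.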